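This account rests on a few compounds, and the source may have more. Where it says the series, first, only, none or still open, it means among the compounds named here.

Measured so far in a functional assay on the whole organism for agonist activity, with Rattus norvegicus as the target; a lower number here means that less compound is needed, a higher number that more compound is needed for the effect:
compound 1 `Clc1cccc2c1CC2CCN1CCN(c2cccc3c2OCCO3)CC1`: 40 mg/kg
compound 2 `Clc1cccc2c1CC2CCCN1CCN(c2cccc3c2OCCO3)CC1`: > 10 mg/kg, a limit of the assay
compound 3 `c1ccc2c(c1)CC(CCN1CCN(c3cccc4c3OCCO4)CC1)C2`: 10 mg/kg

Compound 1 and compound 3 differ by a group of 9 heavy atoms (9 carbon; one five-membered non-aromatic ring of carbon only, one six-membered aromatic ring of carbon only) in place of a group of 9 heavy atoms (8 carbon, 1 chlorine; one four-membered non-aromatic ring of carbon only, one six-membered aromatic ring of carbon only), on a saturated chain carbon, two bonds along the chain from an amine nitrogen in a ring, and this gave a 4.0-fold lower number from compound 1 to compound 3 (0.60 log units; beyond the scatter). Going by the values given here, for compound 2 this assay reports only a limit, > 10 mg/kg, and the only evidence on it is the limit of > 10 mg/kg in this assay, at which 1 of the 3 values shown sits. The difference between the cores of compound 1 and compound 2 is not broken down here.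

Compound 4 `c1ccc2c(c1)CC(CCCN1CCN(c3cccc4c3OCCO4)CC1)C2` is not yet measured. From compound 2 it differs by a group of 9 heavy atoms (9 carbon; one five-membered non-aromatic ring of carbon only, one six-membered aromatic ring of carbon only) in place of a group of 9 heavy atoms (8 carbon, 1 chlorine; one four-membered non-aromatic ring of carbon only, one six-membered aromatic ring of carbon only), on a saturated chain carbon, three bonds along the chain from an amine nitrogen in a ring, the same kind of change as in compound 1 to compound 3, but the place differs: three bonds along the chain from the amine nitrogen in a ring rather than two. A step like a 4.0-fold lower number from compound 1 to compound 3 (0.60 log units; beyond the scatter) is expected, so a number no higher from compound 2 to compound 4 (the limit leaves the size open) is estimated, resting on a 4.0-fold lower number from compound 1 to compound 3 (0.60 log units; beyond the scatter) and on the limit of compound 2. Because compound 2 shows only (the limit of > 10 mg/kg in this assay, at which 1 of the 3 values shown sits), the starting point is uncertain. Compound 4 is estimated at 10 mg/kg, between 3 mg/kg and 40 mg/kg.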

Compound 4, minimum effective dose: 40 mg/kg
Compound 4: the middle estimate sits 4.0-fold (0.60 log units) below what was measured; low and high end bracket the measured number.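

The step from compound 2 to compound 4 cannot be read in this assay, because compound 2 carries only a limit: the limit of > 10 mg/kg in this assay, at which 1 of the 4 values shown sits.

On these data alone, whether the 2,3-dihydro-1H-inden-2-yl group has the same effect three bonds along the chain from the amine nitrogen in a ring as at two bonds remains open.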